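Sulfonylthiourea and sulfonylurea series: blood inhibition working notes

The source may report more compounds than this note shows. Statements on the series, on what has been measured and on what is new or still open speak of the compounds shown alone.

Measured so far:
Compound 1 `Cc1cc(C(=O)O)nn1-c1ccc(S(=O)(=O)NC(=S)NC2CCCCC2)cc1`: 1%
Compound 2 `CCCCNC(=O)NS(=O)(=O)c1ccc(-n2nc(C)cc2C)cc1`: 2%

In a functional assay on the whole organism (blood, strain albino) with Mus musculus as the target, with stated times of 6 days and 4 h, at a dose of 0.4 mmol/kg by the oral route (on this read-out lower numbers stand for less inhibition and higher numbers for more inhibition at the one dose given (going by the name of the read-out)), compound 1 gives 1%, the lowest of the two numbers, while compound 2 gives 2%; the two lie within the scatter of each other, so no order can be read between them. Compound 3 `Cc1cc(C(=O)O)nn1-c1ccc(S(=O)(=O)NC(=S)Nc2ccccc2)cc1` differs from compound 1 by phenyl in place of cyclohexyl on an amide-type nitrogen. Within the data shown here, no measured pair covers this change. In this assay the expected step of a number 2 percentage points higher from compound 1 to compound 3 (within the scatter) is none beyond the scatter. For compound 3 the estimate is 3%, with a range from 0% to 15%.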

Compound 3, a percentage reported as inhibition, in the whole organism at one dose (the size of the read-out at that dose, not a potency): 0%
Beside the measured number, compound 3's estimate is 3 percentage points above it, within the range that was stated.
By their numbers in this assay, from the lowest: compounds 3, 1 and 2 (each within the scatter of the next).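

In this assay, phenyl in place of cyclohexyl on an amide-type nitrogen gives a number 1 percentage points lower from compound 1 to compound 3 (within the scatter). Among these compounds, this is the first step read at this position, and it shows that the aromatic and the non-aromatic six-membered ring cannot be told apart on this read-out at this one dose. Nothing measured here bears on a reason for this result.

No step beyond the scatter is yet available for this nitrogen. As far as these compounds go, whether a benzyl group or an octyl chain there would give a number beyond the scatter of compound 1 remains open.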